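Selenocyanate Carbamates: Branching the Ester Chain

A few compounds are considered here, and "the series" means these few. Any claim that something is new, unique, unknown or untested is made for them only; others in the source may bear on it.

Compound 1 `CCCOC(=O)Nc1ccc([Se]C#N)cc1` carries a propyl carbamate on a ring bearing a selenocyanate. In a functional assay on CCRF-CEM cells (Homo sapiens) for cytotoxicity, read by MTT assay, with a stated time of 72 h (on this read-out higher numbers stand for weaker inhibition of growth and lower numbers for stronger inhibition of growth), compound 1 gives 38400 nM. Among the measured compounds shown here, the only other compound measured, compound 2 `O=C(Nc1ccc([Se][Se]c2ccc(NC(=O)OCc3ccccc3)cc2)cc1)OCc1ccccc1`, a diselenide with benzyl carbamates, gives 34600 nM, a number that lies within the scatter of the value for compound 1, so the two cannot be told apart. Compound 3 `CC(C)COC(=O)Nc1ccc([Se]C#N)cc1` differs from compound 1 by methyl in place of hydrogen on a saturated chain carbon bound to two saturated chain carbons. For the measured compounds named here, with no matched pair to show what such a change does, compound 3 is expected to give 36000 nM (range 15000 nM to 90000 nM), a step of a 1.1-fold lower number from compound 1 to compound 3 (0.03 log units; within the scatter) from compound 1 that is expected to stay within the scatter.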

Compound 3, concentration for total growth inhibition: 38300 nM
Beside the measured number, compound 3's estimate is 1.1-fold (0.03 log units) below it; measured number inside the range.
By their numbers in this assay, from the lowest: compounds 2, 3 and 1 (each within the scatter of the next).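

In this assay, methyl in place of hydrogen on a saturated chain carbon bound to two saturated chain carbons, which turns propyl into isobutyl, gives a 1.0-fold lower number from compound 1 to compound 3 (0.00 log units; within the scatter). Among the compounds shown here, this is the first matched pair in the set, and it shows that this branch on the ester chain makes no readable difference to the result. No measured information bears on why.

Still open, going by these compounds, is whether a longer chain, such as octyl, would behave the same way. The same question stands for a chain ending in an amine or a carboxylic acid.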